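A few compounds are considered here, and "the series" means these few. Any claim that something is new, unique, unknown or untested is made for them only; others in the source may bear on it.

Among the compounds with values here, compound 1 `O=c1nc2ccc(Br)cn2cc1Cc1ccc(Cl)cc1` is the only compound here with a numerical result: in a functional assay on A549 cells (Homo sapiens) for cytotoxicity, read by MTT assay, with a stated time of 24 h (a higher number here means a weaker inhibitor, a lower number a stronger inhibitor), compound 1 gives 105000 nM. Compound 2 `Cc1ccc(Cc2cn3cc(Cl)ccc3nc2=O)cc1` reaches only a limit of the assay, recorded in this assay as > 1000000 nM, which is the case described by the limit of > 1000000 nM in this assay, at which 1 of the 2 values shown sits. Compound 3 `COc1ccc(Cc2cn3cc(Br)ccc3nc2=O)cc1` has not yet been measured. It differs from compound 1 in one place, (methoxy in place of chloro on an aromatic carbon). Within the data shown here, no measured pair shows what such a change does here, so the step is expected to be small, a 1.9-fold higher number from compound 1 to compound 3 (0.28 log units; within the scatter), with no direction beyond the scatter. Compound 3 is estimated at 200000 nM, most likely between 60000 nM and 1000000 nM.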

Compound 3, half-maximal inhibitory concentration: > 1000000 nM
Compound 3 ended at the assay's limit; the forecaster's own chance of this, stated with the estimate: 30%; at least 5.0-fold (0.69 log units) between middle value and limit.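

In this assay, within the data shown here, methoxy in place of chloro on this aromatic carbon gives an at least 9.5-fold higher number from compound 1 to compound 3 (0.97 log units; beyond the scatter), so this single place clearly affects the read-out, a change the earlier compounds could not show. Compound 3 reaches a limit of the assay rather than a number, so the full size of the step stays unknown: the limit of > 1000000 nM in this assay, at which 2 of the 3 values shown sit.

Only chloro and methoxy are compared at this position. Whether another group here, such as fluoro, an amine or a carboxylic acid, would give a lower or higher number remains open, as does the reason for this step.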